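A few compounds are considered here, and "the series" means these few. Any claim that something is new, unique, unknown or untested is made for them only; others in the source may bear on it.

compound 1 `C=C1C(=O)O[C@H]2[C@H]1CC/C(COC(=O)Cn1cc(F)c(=O)n(Cc3ccc(Br)cc3)c1=O)=C\CC[C@@]1(C)O[C@@H]21` - 2670 nM
compound 2 `C=C1C(=O)O[C@H]2[C@H]1CC/C(COC(=O)Cn1cc(F)c(=O)n(Cc3c(F)cccc3F)c1=O)=C\CC[C@@]1(C)O[C@@H]21` - 4500 nM

Both values come from a functional assay on Bel-7402 cells (Homo sapiens) for antiproliferative activity, read by MTT assay, with a stated time of 72 h (a lower number here means a stronger inhibitor, a higher number a weaker inhibitor), and lie within the scatter of each other, so compound 2 holds no separate place in this pair.

Next is compound 3 `C=C1C(=O)O[C@H]2[C@H]1CC/C(COC(=O)Cn1cc(F)c(=O)n(C)c1=O)=C\CC[C@@]1(C)O[C@@H]21`, not yet measured. The change from compound 2 is hydrogen in place of 2,6-difluorophenyl on a saturated chain carbon bound to an aromatic nitrogen, in words hydrogen in place of 2,6-difluorophenyl on a saturated chain carbon bound to an aromatic nitrogen, which also reads as 2,6-difluorobenzyl to methyl.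

For the measured compounds named here, only one measured step bears on this, and only in part. It exchanges 4-bromophenyl for 2,6-difluorophenyl at the same place, so an aromatic ring stays on in both compounds. Going by the values given here, no measured compound lacks that ring, so the data do not show what its removal does. Among the compounds with values here, with a 1.7-fold higher number from compound 1 to compound 2 (0.23 log units; within the scatter) as the sole guide, no step beyond the scatter is expected in this assay, though with low confidence and in no firm direction. The expected step is a 1.1-fold higher number from compound 2 to compound 3 (0.05 log units; within the scatter). For compound 3 the estimated value is 5000 nM, with an expected range of 1800 nM to 14000 nM.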

Compound 3, half-maximal inhibitory concentration: 9400 nM
Compound 3: middle estimate off by 1.9-fold (0.27 log units), on the low side; low and high end bracket the measured number.
By their numbers in this assay, from the lowest: compounds 1 and 2 (each within the scatter of the next); then compound 3.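

In this assay, for the compounds shown here, this is the first view of the position without an aromatic ring: hydrogen in place of 2,6-difluorophenyl gives a 2.1-fold higher number from compound 2 to compound 3 (0.32 log units; beyond the scatter), and hydrogen in place of 4-bromophenyl gives a 3.5-fold higher number from compound 1 to compound 3 (0.55 log units; beyond the scatter). Both steps are modest, but they lie beyond the scatter, whereas the exchange of one aromatic ring for the other, a 1.7-fold higher number from compound 1 to compound 2 (0.23 log units; within the scatter), does not, so among these three compounds having a ring at this position counts for more than which of the two rings is present. No measured data on these compounds account for the step.

Going by these compounds, whether the ring itself matters, or any larger group in its place would serve equally, stays open; cyclohexylmethyl or a longer chain such as n-butyl at this position would separate the two readings. Also open, on these data alone, is how a pyridine ring in place of the phenyl ring, or a chain carrying an amine or a carboxylic acid, would compare with compound 1 and compound 2.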